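Side-chain carbonyl exchange tested on two related cores

A few compounds are considered here, and "the series" means these few. Any claim that something is new, unique, unknown or untested is made for them only; others in the source may bear on it.

Measured compounds:
compound 1 `COc1cc(/C=C/C(=O)/C=C(O)/C=C/c2ccc(O[C@H]3C[C@H]([C@@H](C)CCC=C(C)C)C=C[C@@]3(C)O)c(OC)c2)ccc1O`: 35000 nM
compound 2 `COc1cc(/C=C/C(=O)/C=C(O)/C=C/c2ccc(O[C@H]3C[C@H]([C@@H](C)CC(=O)C=C(C)C)C=C[C@@]3(C)O)c(OC)c2)ccc1O`: 14300 nM
compound 3 `COc1cc(/C=C/C(=O)/C=C(O)/C=C/c2ccc(O[C@]3(C)C=C[C@@H]([C@@H](C)CCC=C(C)C)C[C@@H]3O)c(OC)c2)ccc1O`: 41400 nM

In a functional assay on A549 cells (Homo sapiens) for cytotoxicity, read by crystal violet staining, with a stated time of 72 h (a lower number here means a stronger inhibitor, a higher number a weaker inhibitor), compound 1 gives 35000 nM and compound 2 gives 14300 nM; the change between them is (2-methylprop-1-en-1-yl)carbonyl in place of 3-methylbut-2-en-1-yl on a saturated chain carbon, two bonds along the chain from a saturated ring carbon, and the step is a 2.4-fold lower number from compound 1 to compound 2 (0.39 log units; beyond the scatter). Compound 3 gives 41400 nM in this assay, a number within the scatter of compound 1. The difference between the core of compound 1 and the core of compound 3 is not broken down here. Compound 4 `COc1cc(/C=C/C(=O)/C=C(O)/C=C/c2ccc(O[C@]3(C)C=C[C@@H]([C@@H](C)CC(=O)C=C(C)C)C[C@@H]3O)c(OC)c2)ccc1O` carries the same change on the core of compound 3, namely ((2-methylprop-1-en-1-yl)carbonyl in place of 3-methylbut-2-en-1-yl on a saturated chain carbon, two bonds along the chain from a saturated ring carbon), at the same place as in the first pair. Its value in this assay is not yet known. Among the measured compounds shown here, the expected step is a 2.4-fold lower number from compound 3 to compound 4 (0.39 log units; beyond the scatter), resting on the single measured instance, a 2.4-fold lower number from compound 1 to compound 2 (0.39 log units; beyond the scatter), which is modest but beyond the scatter. On that basis compound 4 is estimated at 17000 nM, in a range from 8000 nM to 40000 nM.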

Compound 4, half-maximal inhibitory concentration: 15200 nM
For compound 4 the middle estimate is 1.1-fold (0.05 log units) above the measured one; the measured number falls inside the stated range.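

The exchange of 3-methylbut-2-en-1-yl for (2-methylprop-1-en-1-yl)carbonyl gives a 2.7-fold lower number from compound 3 to compound 4 (0.44 log units; beyond the scatter) in this assay. Set beside the step on the core of compound 1, it carries over in direction and size, with no difference between the two cores: the same change on two cores in this assay, a 2.4-fold lower number (0.39 log units; beyond the scatter) from compound 1 to compound 2 and a 2.7-fold lower number (0.44 log units; beyond the scatter) from compound 3 to compound 4, 1.1-fold (0.05 log units) apart, within the scatter of two such steps This holds for two cores in one assay only; it does not show that the step would carry to any other core or cell line, nor which part of the entering group accounts for it.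

Open, from the compounds shown here alone, is whether a saturated ketone chain or a hydroxyl group would give a similar step. Also open, going by these compounds, is how a longer chain or an amine at this place would compare.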